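Swapping the Alkyne Terminus for a Tertiary Alcohol

The source may report more compounds than this note shows. Statements on the series, on what has been measured and on what is new or still open speak of the compounds shown alone.

Compound 2 `C#CCCCCOc1cc(O)c(C(C)=O)cc1CC=C` stands highest of the two measured compounds in an assay on isolated protein for inhibition of leukotriene B4 receptor 1 (Homo sapiens), tested at 10 uM (a lower number here means less inhibition, a higher number more inhibition at the concentration tested (going by the name of the read-out)), where compound 2 gives 74%; compound 1 `C=CCc1cc(C(C)=O)c(O)cc1OCCCCCCCCCCC#N` gives 50%. Among the compounds with values here, the single measured step, a number 24 percentage points higher from compound 1 to compound 2 (beyond the scatter), is the only one that bears on compound 3 `C=CCc1cc(C(C)=O)c(O)cc1OCCCCCC(C)(C)O`, which differs from compound 2 by 2-hydroxy-2-methylpropyl in place of ethynyl on a saturated chain carbon, four bonds along the chain from an oxygen on an aromatic ring. Since the measured step gained inhibition on going from the longer 6-cyanohexyl to ethynyl, a return to a longer 2-hydroxy-2-methylpropyl terminus is expected to give back part of that gain. Compound 3 is therefore estimated at 55% (range 30% to 80%), an expected a number 19 percentage points lower from compound 2 to compound 3 (beyond the scatter).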

Compound 3, a percentage reported as inhibition, at one concentration (the size of the read-out at that concentration, not a potency): 98%
Compound 3: middle estimate off by 43 percentage points, on the low side; the whole stated range lies below it.
By their numbers in this assay, from the lowest: compound 1; then compound 2; then compound 3.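

At this chain carbon, four bonds along the chain from an oxygen on an aromatic ring, 2-hydroxy-2-methylpropyl in place of ethynyl gives a number 24 percentage points higher from compound 2 to compound 3 (beyond the scatter) in this assay, so a larger terminus need not lose inhibition here. Set against the nitrile-ended chain, the tertiary alcohol gives a number 48 percentage points higher from compound 1 to compound 3 (beyond the scatter), and across these three compounds the order does not follow chain length alone. Nothing available here explains the gain. From the compounds shown here alone, whether the hydroxyl or the two methyl groups carry it remains open, as does whether an amine or a carboxylic acid at the chain end would keep it.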